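The source may report more compounds than this note shows. Statements on the series, on what has been measured and on what is new or still open speak of the compounds shown alone.

Measured in an ADME assay (liver) for metabolic stability, with Liver microsome (Rattus norvegicus) as the target, using microsomes; a higher number here means faster removal of the compound, a lower number slower removal:
- compound 1 `CN(C(=O)c1ccncc1)c1ccc(OCB2C=Cc3ccccc3N2)cc1`: 115 mL/min/kg
- compound 2 `Cn1cc(-c2ccncc2)c(-c2ccc(OCB3C=Cc4ccccc4N3)cc2)n1`: 41.7 mL/min/kg
- compound 3 `CN(C(=O)c1ccncc1)c1ccc(OCc2ccc3ccccc3n2)cc1`: 15 mL/min/kg

Compound 1 stands highest of the three, with compound 2 and compound 3 both lower by more than the usual scatter. Compound 4 `CN(C(=O)c1csc(-c2cccnc2)n1)c1ccc(OCB2C=Cc3ccccc3N2)cc1` has not yet been measured. It keeps the rest of compound 1 but carries 2-(pyridin-3-yl)-1,3-thiazol-4-yl in place of pyridin-4-yl on a carbonyl carbon.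

Among the compounds with values here, no measured pair isolates a change of this kind, so the data give no direct guide to its size. Within the data shown here, the only other compound that keeps the boron-containing end of compound 1 is compound 2, at 41.7 mL/min/kg, which suggests that this end need not hold the number at the top of the range. A moderate fall in this assay is therefore expected, though it may not clear the scatter. The expected step is a 1.6-fold lower number from compound 1 to compound 4 (0.22 log units; within the scatter). For compound 4 the estimated value is 70 mL/min/kg, with an expected range of 30 mL/min/kg to 150 mL/min/kg.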

Compound 4, clearance: > 283 mL/min/kg
Compound 4 ended at the assay's limit; the forecaster's own chance of this, stated with the estimate: 3%; middle value at least 4.0-fold (0.60 log units) away from the limit.
By their numbers in this assay, from the lowest: compound 3; then compound 2; then compound 1. At a limit, above all of these: compound 4.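

In this assay, putting 2-(pyridin-3-yl)-1,3-thiazol-4-yl in place of pyridin-4-yl on the carbonyl carbon gives an at least 2.4-fold higher number from compound 1 to compound 4 (0.39 log units; beyond the scatter), which shows that a change at this place can move the number, and here it moves it upward, beyond the scatter. Compound 4 reads > 283 mL/min/kg, which is a limit of the assay and not a number. The step therefore fixes only a floor for the change and not its size: the limit of > 283 mL/min/kg in this assay, at which 1 of the 4 values shown sits.

The five-membered ring and the six-membered ring of the entering group arrive together, so the compounds shown do not tell which of them goes with the rise. Going by these compounds, it also stays open how a plain phenyl, or a pyridin-4-yl carrying an amine, would read at this place.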